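A few compounds are considered here, and "the series" means these few. Any claim that something is new, unique, unknown or untested is made for them only; others in the source may bear on it.

Measured compounds:
compound 1 `c1ccc(Oc2ccc3c(NCCCNCc4ccco4)ccnc3c2)cc1` with 15200 nM
compound 2 `FC(F)(F)c1ccc(-c2ccc3c(NCCCNCc4ccco4)ccnc3c2)cc1` with 3470 nM
compound 3 `c1coc(CNCCCNc2ccnc3cc(CC4CCCCC4)ccc23)c1` with 1700 nM

In an ADME assay on HepG2 cells (Homo sapiens) for cytotoxicity, read by luminescence, CellTiter-Glo and ATP content, with a stated time of 72 h (on this read-out higher numbers stand for an effect only at larger amounts of compound and lower numbers for an effect already at smaller amounts), compound 2 stands second highest of the three numbers: compound 3 is nearest with the step of a 2.0-fold lower number from compound 2 to compound 3 (0.31 log units; beyond the scatter), and compound 1 is furthest with the step of a 4.4-fold lower number from compound 1 to compound 2 (0.64 log units; beyond the scatter) running the other way. The third measured step, an 8.9-fold lower number from compound 1 to compound 3 (0.95 log units; beyond the scatter), like the other two, changes only the group on an aromatic carbon of the shared core.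

Compound 4 `COc1ccc(F)cc1CNCCCNc1ccnc2cc(-c3ccc(C(F)(F)F)cc3)ccc12` differs from compound 2 at another place: 5-fluoro-2-methoxyphenyl in place of furan-2-yl on a saturated chain carbon bound to an amine nitrogen. For the measured compounds named here, no measured step touches the saturated chain carbon bound to an amine nitrogen, so the three steps bear on the change only indirectly, showing that single replacements have moved this assay by modest amounts. Compound 4 is therefore expected to stay near compound 2, with a step of a 1.2-fold lower number from compound 2 to compound 4 (0.06 log units; within the scatter) at most, in no firm direction. The estimate for compound 4 in this assay is 3000 nM, within 1200 nM to 8000 nM.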

Compound 4, half-maximal effective concentration: 5190 nM
For compound 4 the middle estimate is 1.7-fold (0.24 log units) below the measured one; low and high end bracket the measured number.
By their numbers in this assay, from the lowest: compound 3; then compounds 2 and 4 (each within the scatter of the next); then compound 1.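

Compound 4 carries the first change shown on the saturated chain carbon bound to an amine nitrogen, and in this assay putting 5-fluoro-2-methoxyphenyl in place of furan-2-yl gives a 1.5-fold higher number from compound 2 to compound 4 (0.17 log units; within the scatter). Compounds 2 and 4 therefore cannot be told apart here, even though a six-membered aromatic ring of carbon only replaces a five-membered aromatic ring with 1 hetero atom, whereas all three earlier steps, each on an aromatic carbon of the shared core, lay beyond the scatter. No supporting data are available to account for this result.

Going by these compounds, whether a plain benzyl group or a pyridine ring at this place would also leave this assay within the scatter stays open. So does whether 5-fluoro-2-methoxyphenyl would behave the same way alongside the cyclohexylmethyl group of compound 3 or the phenoxy group of compound 1.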